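This account rests on a few compounds, and the source may have more. Where it says the series, first, only, none or still open, it means among the compounds named here.

Three sulfonamides built on a benzoxazole scaffold have been tested so far. Compound 1 `O=S(=O)(Nc1ccc(-c2nc3ccccc3o2)cc1)c1cccc(O)c1` carries a 3-hydroxyphenyl on the sulfonyl sulfur. In an assay on cells for inhibition of HSP60/HSP10 (Homo sapiens), with a stated time of 60 min (a lower number here means a stronger inhibitor, a higher number a weaker inhibitor), compound 1 gives 62000 nM. Compound 2 `O=S(=O)(Nc1ccc(-c2nc3ccccc3o2)cc1)c1cccs1` keeps the same core but has a thiophen-2-yl in place of the 3-hydroxyphenyl: thiophen-2-yl in place of 3-hydroxyphenyl on a sulfonyl sulfur. In this assay compound 2 gives 63000 nM. The step of a 1.0-fold higher number from compound 1 to compound 2 (0.01 log units; within the scatter) shows that this swap left the result essentially where it was. Compound 3 `O=S(=O)(Nc1ccc2oc(-c3ccccc3)nc2c1)c1cccc(O)c1` has the same atoms as compound 1 joined differently, so the sulfonamide sits on a different position of the core; the difference between the two cores is not broken down here. In this assay compound 3 gives 76000 nM, a number within the usual scatter of both compound 1 and compound 2.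

Compound 4 `O=S(=O)(Nc1ccc2oc(-c3ccccc3)nc2c1)c1cccs1` has not yet been measured. It relates to compound 3 exactly as compound 2 relates to compound 1: thiophen-2-yl in place of 3-hydroxyphenyl on a sulfonyl sulfur. Since both "place" descriptions read the same, this is the same change. Because the step of a 1.0-fold higher number from compound 1 to compound 2 (0.01 log units; within the scatter) was flat, the expected step of a 1.0-fold higher number from compound 3 to compound 4 (0.01 log units; within the scatter) is likewise close to nothing. Among the measured compounds shown here, compound 4 is therefore estimated at 78000 nM, with a likely range from 35000 nM to 170000 nM, resting only on the single earlier pair and on the value of compound 3.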

Compound 4, half-maximal inhibitory concentration: 90000 nM
Estimate against measurement, compound 4: 1.2-fold (0.06 log units) below; low and high end bracket the measured number.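

In this assay, putting thiophen-2-yl in place of 3-hydroxyphenyl on the sulfonyl sulfur gives a 1.2-fold higher number from compound 3 to compound 4 (0.07 log units; within the scatter), so on this second core the swap again leaves the result within the usual scatter. Set side by side, the two pairs show no difference in how this swap behaves on the two cores: the same change on two cores in this assay, a 1.0-fold higher number (0.01 log units; within the scatter) from compound 1 to compound 2 and a 1.2-fold higher number (0.07 log units; within the scatter) from compound 3 to compound 4, 1.2-fold (0.07 log units) apart, within the scatter of two such steps. Among the compounds shown here, this shows that, for these two cores, a flat result on one core went with a flat result on the other, but it rests on only two pairs and does not show that the swap would stay flat on any further core, nor does it explain why the swap changes so little.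

From the compounds shown here alone, a swap with no visible effect is also a mild test of carrying a change across cores, and it remains open whether a step large enough to stand clear of the scatter would repeat from one core to the other. Also open, going by these compounds, is what other groups on the sulfonyl sulfur, such as an aminophenyl, a carboxyphenyl or a plain butyl chain, would do on either core.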